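A few compounds are considered here, and "the series" means these few. Any claim that something is new, unique, unknown or untested is made for them only; others in the source may bear on it.

Measured compounds:
- compound 1 `COc1ccc([C@@H]2CCc3c(OC)cc(OC)cc3O2)cc1`: 29000 nM
- compound 2 `CC(C)(O)[C@@H](O)Cc1c(O)cc(O)c2c(=O)c(-c3ccc(O)cc3)coc12`: > 100000 nM (a limit of the assay)
- compound 3 `COc1cc(O)c(-c2coc3cc(O)ccc3c2=O)cc1OC`: > 100000 nM (a limit of the assay)

Among the measured compounds shown here, in a functional assay on U-937 cells (Homo sapiens) for antiproliferative activity, read by WST assay, with a stated time of 24 h (on this read-out lower numbers stand for stronger inhibition and higher numbers for weaker inhibition), compound 1 gives 29000 nM, and this is the only value among the three that is a number. Compound 2 does not reach a number and is reported only at the limit > 100000 nM. Compound 3 likewise stops at the limit > 100000 nM. For the measured compounds named here, compound 1 therefore stands alone as the single compound with a measured concentration, while the other two sit at the limit of > 100000 nM in this assay, at which 2 of the 3 values shown sit.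

Compound 4 `COc1ccc([C@@H]2CCc3c(OC)cc(OC)cc3O2)c(OC)c1` is built on the core of compound 1 and differs from it by methoxy in place of hydrogen on an aromatic carbon. Going by the values given here, no pair of measured compounds shows what such a change does in this assay, so no measured step can be drawn on. The author expects the step from compound 1 to compound 4 to be small, without a clear direction and not beyond the usual scatter. Compound 4 is accordingly estimated at 25000 nM, with a range from 8000 nM to 80000 nM, a step of a 1.2-fold lower number from compound 1 to compound 4 (0.06 log units; within the scatter) that is expected rather than known.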

Compound 4, half-maximal inhibitory concentration: > 100000 nM
Compound 4: only a limit was reported; the forecaster's own chance of this, stated with the estimate: 15%; middle value at least 4.0-fold (0.60 log units) away from the limit.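

In this assay, compound 4 is reported only at a limit, > 100000 nM. Methoxy in place of hydrogen on an aromatic carbon, ortho to a large group and meta to a methoxy group, therefore gives an at least 3.4-fold higher number from compound 1 to compound 4 (0.53 log units; beyond the scatter), the first measured evidence that a change at this position of the core of compound 1 is not neutral in this read-out. The one added methoxy moves the only compound with a measured number to the limit shared by the others: the limit of > 100000 nM in this assay, at which 3 of the 4 values shown sit.

On these data alone, how far beyond the limit compound 4 lies remains unknown, so the step has a lower bound but no full size. As far as these compounds go, whether a fluorine, a hydroxyl or an amine at this position would stay near compound 1, which gives 29000 nM, also remains open.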